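Cytotoxicity notes: the step from compound 1 to compound 3

This account rests on a few compounds, and the source may have more. Where it says the series, first, only, none or still open, it means among the compounds named here.

compound 1 `CN(C)C12CC(c3ccccc3)C(CN(C(=O)CN3CCCC3)C1)C(c1ccccc1)C2` gives 12600 nM
compound 2 `CN1CCN(CC(=O)N2CC3C(c4ccccc4)CC(N(C)C)(CC3c3ccccc3)C2)CC1` gives 9250 nM

Among the measured compounds shown here, in an ADME assay on L6 cells (Rattus norvegicus) for cytotoxicity, read by resazurin assay, with a stated time of 72 h (on this read-out lower numbers stand for stronger inhibition and higher numbers for weaker inhibition), compound 1 stands level with compound 2, the only other measured compound: a 1.4-fold lower number from compound 1 to compound 2 (0.13 log units; within the scatter). Compound 3 `CN(C)C12CC(c3ccccc3)C(CN(C(=O)CCN3CCCCC3)C1)C(c1ccccc1)C2` differs from compound 1 by (piperidin-1-yl)methyl in place of pyrrolidin-1-yl on a saturated chain carbon bound to a carbonyl carbon. For the measured compounds named here, the measured step replaces pyrrolidin-1-yl at this same place and is the only one bearing on the change. Going by the values given here, no measured compound carries 2-(piperidin-1-yl)ethyl, so the range stays wide. No shift beyond the scatter is expected, and the expected step is a 1.3-fold lower number from compound 1 to compound 3 (0.10 log units; within the scatter). For compound 3 the estimated value is 10000 nM, with an expected range of 4500 nM to 22000 nM.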

Compound 3, half-maximal inhibitory concentration: 12400 nM
Compound 3: the middle estimate sits 1.2-fold (0.09 log units) below what was measured; the range from low to high includes it.
By their numbers in this assay, from the lowest: compounds 2, 3 and 1 (each within the scatter of the next).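

In this assay, (piperidin-1-yl)methyl in place of pyrrolidin-1-yl on a saturated chain carbon bound to a carbonyl carbon gives a 1.0-fold lower number from compound 1 to compound 3 (0.01 log units; within the scatter), and in place of 4-methylpiperazin-1-yl it gives a 1.3-fold higher number from compound 2 to compound 3 (0.13 log units; within the scatter). The three groups at this place now stand within the scatter of each other, so neither the six-membered ring nor the 2-(piperidin-1-yl)ethyl chain separates these compounds. No further data bear on this result. Open, going by these compounds, is whether a carboxylic acid or a primary amine at this place, or a chain longer than 2-(piperidin-1-yl)ethyl, would move the number beyond the scatter.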